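Removing the methyl from compound 1

The source may hold more compounds than are shown below. What is called first, only, known or untested is meant among the compounds shown, and "the series" means these compounds.

Compound 1 `Cc1ccc2[nH]c(-c3ccc(-c4ccc(-c5cccc(Cl)c5)cc4)cc3)nc2c1`: 2800 nM
Compound 2 `COc1cc(-c2ccc(-c3ccc(-c4nc5cc(C)ccc5[nH]4)cc3)cc2)cc(OC)c1OC`: < 100 nM (a limit)
Compound 3 `COc1ccc(-c2ccc(-c3ccc(-c4nc5ccccc5[nH]4)cc3)cc2)cc1`: 38100 nM

In a functional assay on A549 cells (Homo sapiens) for inhibition, read by sulforhodamine B assay (on this read-out lower numbers stand for stronger inhibition of growth and higher numbers for weaker inhibition of growth), compound 1 gives 2800 nM, the lower of the two exact numbers in this small set. Compound 3 gives the higher number, 38100 nM, and its gap to compound 1 lies beyond the scatter. Compound 2 is reported only as a limit, < 100 nM.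

The next compound to be tested is compound 4 `Clc1cccc(-c2ccc(-c3ccc(-c4nc5ccccc5[nH]4)cc3)cc2)c1`. Compared with compound 1, hydrogen replaces methyl on an aromatic carbon (hydrogen in place of methyl on an aromatic carbon). For the measured compounds named here, no measured pair in the set isolates this change, so the expectation is only loosely anchored. A modest move towards weaker inhibition of growth in this assay is expected, and it may not clear the scatter. The direction leans on compound 3, with its value of 38100 nM. The expected change is a 2.1-fold higher number from compound 1 to compound 4 (0.33 log units; beyond the scatter). For compound 4 the estimated value is 6000 nM, with an expected range from 1500 nM to 25000 nM.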

Compound 4, concentration for 50% growth inhibition: 31100 nM
The estimate for compound 4 lay 5.2-fold (0.71 log units) below the measured number; measured number outside the range, above it.
By their numbers in this assay, from the lowest: compound 1; then compounds 4 and 3 (each within the scatter of the next). At a limit, below all of these: compound 2.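

In this assay, for the compounds shown here, the methyl on the core of compound 1 counts for much of the number: an 11-fold higher number from compound 1 to compound 4 (1.05 log units; beyond the scatter) is a large step and the first measured pair that isolates hydrogen in place of methyl on an aromatic carbon. Without that methyl, a 1.2-fold lower number from compound 3 to compound 4 (0.09 log units; within the scatter) shows that 3-chlorophenyl in place of 4-methoxyphenyl makes no difference beyond the scatter, so this exchange at the far end of the molecule does not replace what the methyl gives. Nothing measured here accounts for the size of the methyl step.

Compound 2 stands only as a limit, so it leaves open whether the methyl step would keep its size with other end groups. Also open, from the compounds shown here alone, is how an ethyl group or an amine on the same aromatic carbon would compare with methyl.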